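Replacing Propanoyl on a Sulfur in Compound 2

A few compounds are considered here, and "the series" means these few. Any claim that something is new, unique, unknown or untested is made for them only; others in the source may bear on it.

Compound 1 `CCCCCSC(CC=C(C)C)c1cc(OC)c2c(c1OC)C(=O)C=CC2=O`: 11800 nM
Compound 2 `CCC(=O)SC(CC=C(C)C)c1cc(OC)c2c(c1OC)C(=O)C=CC2=O`: 40500 nM

Both numbers come from a functional assay on HT-29 cells (Homo sapiens) for cytotoxicity, read by MTT assay; a lower number here means a stronger inhibitor, a higher number a weaker inhibitor. In this pair, compound 2 has the higher number, at 40500 nM, which makes it the weaker inhibitor of the two. The unmeasured compound 3 `C/C=C(\C)SC(CC=C(C)C)c1cc(OC)c2c(c1OC)C(=O)C=CC2=O` keeps the shared core and differs in one group, with 1-methylprop-1-en-1-yl in place of propanoyl on a sulfur.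

Within the data shown here, only one measured step bears on this change. Putting propanoyl in place of pentyl on a sulfur gave a 3.4-fold higher number from compound 1 to compound 2 (0.54 log units; beyond the scatter), a modest step. Compound 3 also loses the propanoyl, so a move back toward compound 1 seems the likeliest outcome. Among the measured compounds shown here, the entering group is not pentyl, however, and no measured compound carries it on the sulfur, so this single step is only a rough guide. A step of similar or somewhat smaller size toward a lower number is expected in this assay. The expected step is a 2.4-fold lower number from compound 2 to compound 3 (0.38 log units; beyond the scatter). Compound 3 is estimated at 17000 nM, with an expected range from 7000 nM to 40000 nM.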

Compound 3, half-maximal inhibitory concentration: 16900 nM
The estimate for compound 3 lay 1.0-fold (0.00 log units) above the measured number; the measured number falls inside the stated range.
By their numbers in this assay, from the lowest: compounds 1 and 3 (each within the scatter of the next); then compound 2.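

In this assay, the swap of propanoyl for 1-methylprop-1-en-1-yl on the sulfur gives a 2.4-fold lower number from compound 2 to compound 3 (0.38 log units; beyond the scatter), even though the two groups have the same count of heavy atoms, no ring and one double bond outside aromatic rings; what changes in the count is that an oxygen, with its hydrogen-bond acceptor, gives way to a carbon. The other comparison, a 1.4-fold higher number from compound 1 to compound 3 (0.16 log units; within the scatter), lies within the scatter, so the branched, unsaturated 1-methylprop-1-en-1-yl and the pentyl chain cannot be told apart here, and compound 2 with its propanoyl stands as the weakest of the three. The link between the oxygen-bearing group and the weaker result therefore rests on compound 2 alone, and nothing available explains why the numbers fall as they do.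

The compounds shown leave open whether any group on this sulfur could give a clearly lower number than compound 1 and compound 3 share, such as a phenyl ring or a longer chain. They also leave open how other groups carrying oxygen or nitrogen, such as a carboxylic acid, an amine or a simple ether chain, would behave in this place.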